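The source may hold more compounds than are shown below. What is called first, only, known or untested is meant among the compounds shown, and "the series" means these compounds.

Compound 1 `Oc1ccccc1-c1cc(-c2cccs2)cc(-c2ccccc2O)n1` and compound 2 `Oc1cccc(-c2cc(-c3cccs3)cc(-c3ccccc3O)n2)c1` share a core in which a thiophen-2-yl group and two hydroxyphenyl groups hang from a six-membered aromatic ring with 1 nitrogen. In an assay on isolated protein for inhibition of DNA topoisomerase 1 (Homo sapiens), with a stated time of 30 min, tested at 20 uM (on this read-out lower numbers stand for a weaker effect and higher numbers for a stronger effect at the one concentration tested), compound 1 gives 0.2%, and compound 2 gives 1.5%. Compound 2 stands alongside compound 1 here: the two are separated only by a number 1.3 percentage points higher from compound 1 to compound 2 (within the scatter), so no difference between them can be claimed. Both numbers are small on a scale that runs to full inhibition.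

Compound 3 `Oc1cccc(-c2cc(-c3cccs3)cc(-c3cccc(O)c3)n2)c1` is not yet measured. It differs from compound 2 in one place (3-hydroxyphenyl in place of 2-hydroxyphenyl on an aromatic carbon). Among the compounds with values here, the only step already measured that bears on this is the one from compound 1 to compound 2, where the same exchange of a 2-hydroxyphenyl for a 3-hydroxyphenyl, on an aromatic carbon next to the ring nitrogen, produced a number 1.3 percentage points higher from compound 1 to compound 2 (within the scatter). Repeating that exchange on the remaining 2-hydroxyphenyl is therefore expected to leave this assay essentially unchanged, as a step of a number 0.5 percentage points higher from compound 2 to compound 3 (within the scatter) that stays within the scatter. Compound 3 is thus estimated to give 2%, in a range from 0% to 10%.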

Compound 3, a percentage reported as inhibition, at one concentration (the size of the read-out at that concentration, not a potency): 0%
For compound 3 the middle estimate is 2 percentage points above the measured one, within the range that was stated.
By their numbers in this assay, from the lowest: compounds 3, 1 and 2 (each within the scatter of the next).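

In this assay, the exchange of 2-hydroxyphenyl for 3-hydroxyphenyl on an aromatic carbon next to the ring nitrogen now gives a number 1.5 percentage points lower from compound 2 to compound 3 (within the scatter), so this second reading of the change also shows no difference that can be claimed. The earlier step, a number 1.3 percentage points higher from compound 1 to compound 2 (within the scatter), was read with a 2-hydroxyphenyl group remaining on the far side of the core, whereas this one was read with a 3-hydroxyphenyl group there, meta to the place of change, and that different partner did not bring out a difference either. No measurement at hand explains these numbers.

The compounds shown therefore leave open whether this position can affect the read-out at all, since only two placements of one hydroxyl group have been compared there, and a 4-hydroxyphenyl group, an amine or a carboxylic acid at the same place could behave differently. The thiophen-2-yl group is also the same in every compound shown, so what a plain phenyl group or a longer chain would do in its place remains an open question.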